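Methyl addition on the anilide ring of the chromone series

The source may hold more compounds than are shown below. What is called first, only, known or untested is meant among the compounds shown, and "the series" means these compounds.

Compound 1 `Cc1ccc(NC(=O)COc2ccc3c(=O)ccoc3c2)cc1NC(=O)c1ccc(N(C)C)cc1` gives 1040 nM in an assay on isolated protein for inhibition of Rho-associated protein kinase 1 (Homo sapiens), read by scintillation counting, radiometric assay and 33P incorporation, with a stated time of 40 min, in the presence of a further agent that is not named here; a higher number here means a weaker inhibitor, a lower number a stronger inhibitor. Compound 2 `Cc1cc(NC(=O)COc2ccc3c(=O)ccoc3c2)cc(NC(=O)c2ccc(N(C)C)cc2)c1` gives > 10000 nM in this assay, a limit of the assay and not a number (the limit of > 10000 nM in this assay, at which 1 of the 2 values shown sits). Compound 3 `Cc1cc(NC(=O)COc2ccc3c(=O)ccoc3c2)cc(NC(=O)c2ccc(N(C)C)cc2)c1C` differs from compound 2 by methyl in place of hydrogen on an aromatic carbon. For the measured compounds named here, with compound 2 already at the limit, no step that the assay could resolve is expected, and compound 3 is expected to remain at or beyond that limit, with the step from compound 2 to compound 3 estimated at a step that the limit leaves unreadable from compound 2 to compound 3. The value of compound 3 is estimated at 15000 nM, within 5000 nM to 50000 nM.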

Compound 3, half-maximal inhibitory concentration: 3950 nM
The estimate for compound 3 lay 3.8-fold (0.58 log units) above the measured number; measured number below the stated range.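

In this assay, methyl on the aromatic carbon ortho to the ((4-(dimethylamino)phenyl)carbonyl)amino group and ortho to a methyl group gives an at least 2.5-fold lower number from compound 2 to compound 3 (0.40 log units; beyond the scatter). This position therefore affects the read-out, but the gain is partial, with a 3.8-fold higher number from compound 1 to compound 3 (0.58 log units; beyond the scatter). Compound 2 stands at a limit of the assay and not at a number, so the full size of its step stays unknown: the limit of > 10000 nM in this assay, at which 1 of the 3 values shown sits.

On these data alone, whether an ethyl group, a methoxy group or a chlorine atom at this position would give a similar step remains open.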